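Swapping the Sulfonyl Aryl Group: Naphthyl to Nitrophenyl

The source may report more compounds than this note shows. Statements on the series, on what has been measured and on what is new or still open speak of the compounds shown alone.

Three measured compounds share one core, an amide on one side and a sulfonamide on the other, and differ only in the aryl group on the sulfonyl sulfur. In an assay on MDA-MB-231 cells for displacement of a labelled ligand from C-X-C chemokine receptor type 4 (Homo sapiens), read by fluorescence and microscopy, with stated times of 10 min and 30 min (on this read-out lower numbers stand for an effect already at smaller amounts and higher numbers for an effect only at larger amounts of compound), compound 1 `Cc1ccccc1C(=O)NCc1ccc(CNS(=O)(=O)c2ccccc2C)cc1` gives 10 nM. Compound 2 `Cc1ccccc1C(=O)NCc1ccc(CNS(=O)(=O)c2ccccc2Cl)cc1` gives 1000 nM in this assay. Compound 3 `Cc1ccccc1C(=O)NCc1ccc(CNS(=O)(=O)c2cccc3ccccc23)cc1` gives 100 nM in this assay. Compound 3 therefore stands second highest of the three numbers, lying between the other two: a 10-fold higher number from compound 1 to compound 3 (1.00 log units; beyond the scatter) and a 10-fold lower number from compound 2 to compound 3 (1.00 log units; beyond the scatter).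

Compound 4 `Cc1ccccc1C(=O)NCc1ccc(CNS(=O)(=O)c2ccc([N+](=O)[O-])cc2)cc1` arises from compound 3 by a single change: 4-nitrophenyl in place of naphthalen-1-yl on a sulfonyl sulfur. Within the data shown here, the steps that bear on this are the two swaps of the aryl group on the sulfonyl sulfur, a 10-fold higher number from compound 1 to compound 3 (1.00 log units; beyond the scatter) and a 10-fold lower number from compound 2 to compound 3 (1.00 log units; beyond the scatter), each modest, while a 100-fold higher number from compound 1 to compound 2 (2.00 log units; beyond the scatter) shows that one substituent swap on that ring can be large. Among the measured compounds shown here, no measured compound carries a nitro group, so the direction cannot be read from the data. Compound 4 is expected to land near compound 3, with a 3.0-fold higher number from compound 3 to compound 4 (0.48 log units; beyond the scatter) as the likeliest outcome; the estimate for compound 4 is 300 nM, within 30 nM to 3000 nM.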

Compound 4, effective concentration (reported as EC, without a stated level of effect): 100 nM
Estimate against measurement, compound 4: 3.0-fold (0.48 log units) above; measured number inside the range.
By their numbers in this assay, from the lowest: compound 1; then compounds 3 and 4 (each within the scatter of the next); then compound 2.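

In this assay, 4-nitrophenyl in place of naphthalen-1-yl on the sulfonyl sulfur gives no change at the digits printed from compound 3 to compound 4 (within the scatter), so a single ring bearing a nitro group and a two-ring aryl group of carbon only cannot be told apart here. Measured against the two other aryl groups, the new group gives a 10-fold lower number from compound 2 to compound 4 (1.00 log units; beyond the scatter) and a 10-fold higher number from compound 1 to compound 4 (1.00 log units; beyond the scatter), steps that match in size those printed for compound 3. A swap of the whole aryl group can thus leave the number unchanged, whereas chloro in place of methyl gave a 100-fold higher number from compound 1 to compound 2 (2.00 log units; beyond the scatter).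

Nothing shown gives a reason for these numbers. Still open, on these data alone, is how a phenyl ring carrying an amine or a carboxylic acid in place of the nitro group would read in this assay.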